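Dimethylamino in place of phenylsulfanyl on the pyrazole series

The source may report more compounds than this note shows. Statements on the series, on what has been measured and on what is new or still open speak of the compounds shown alone.

Measured compounds:
compound 1, `Cc1nn(C)c(N2CCCC2)c1/C=N/OCc1ccc(C(=O)OC(C)(C)C)cc1`, 14.4 ug/mL
compound 2, `Cc1nn(C)c(-n2ccnc2)c1/C=N/OCc1ccc(C(=O)OC(C)(C)C)cc1`, 9.35 ug/mL
compound 3, `Cc1nn(C)c(Sc2ccccc2)c1/C=N/OCc1ccc(C(=O)OC(C)(C)C)cc1`, 4.91 ug/mL

All three share one core and differ only in the group on one aromatic carbon of the five-membered ring. In a functional assay on SK-MEL-2 cells (Homo sapiens) for cytotoxicity (on this read-out higher numbers stand for weaker inhibition and lower numbers for stronger inhibition), compound 3 gives the lowest number of the three; its gap to compound 2 is within the scatter, while a 2.9-fold lower number from compound 1 to compound 3 (0.47 log units; beyond the scatter) is beyond it. The step of a 1.9-fold lower number from compound 2 to compound 3 (0.28 log units; within the scatter) is also within the scatter.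

Compound 4 is `Cc1nn(C)c(N(C)C)c1/C=N/OCc1ccc(C(=O)OC(C)(C)C)cc1`. The change from compound 3 is dimethylamino in place of phenylsulfanyl on an aromatic carbon. The bearing steps are a 2.9-fold lower number from compound 1 to compound 3 (0.47 log units; beyond the scatter) and a 1.9-fold lower number from compound 2 to compound 3 (0.28 log units; within the scatter): the phenylsulfanyl compound 3 sits lower than both ring-bearing alternatives. Dimethylamino, like pyrrolidin-1-yl in compound 1, is attached through nitrogen and carries no ring, so the expected direction is back toward the number of compound 1, that is a higher number. The step of a 2.4-fold higher number from compound 3 to compound 4 (0.39 log units; beyond the scatter) is therefore expected to be modest and upward, about the reverse of a 2.9-fold lower number from compound 1 to compound 3 (0.47 log units; beyond the scatter). Compound 4 is estimated at 12 ug/mL, within 6 ug/mL to 25 ug/mL.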

Compound 4, half-maximal inhibitory concentration: 23.9 ug/mL
Compound 4: middle estimate off by 2.0-fold (0.30 log units), on the low side, and the stated range covers the measured number.
By their numbers in this assay, from the lowest: compounds 3, 2, 1 and 4 (each within the scatter of the next, the first and the last beyond it).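

In this assay, among these compounds, this position now spans a wider range than the earlier compounds showed: a 4.9-fold higher number from compound 3 to compound 4 (0.69 log units; beyond the scatter) is the largest step, and a 2.6-fold higher number from compound 2 to compound 4 (0.41 log units; beyond the scatter) separates dimethylamino from 1H-imidazol-1-yl as well. Dimethylamino and pyrrolidin-1-yl stay together, with a 1.7-fold higher number from compound 1 to compound 4 (0.22 log units; within the scatter) so that neither can be placed ahead of the other. Among these compounds, phenylsulfanyl is thus beyond the scatter of both dimethylamino and pyrrolidin-1-yl, and nothing measured here speaks to the origin of these steps.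

From the compounds shown here alone, whether the sulfur link or the aromatic ring of phenylsulfanyl goes with the lower number remains open. A phenoxy or anilino group on the same carbon, keeping the ring while replacing the sulfur, would address this.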